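Swapping the anilino aryl on the trimethoxyphenyl core

The source may report more compounds than this note shows. Statements on the series, on what has been measured and on what is new or still open speak of the compounds shown alone.

Measured compounds:
compound 1, `CC(C)c1ccc(-c2nc(SCc3cn(CC(=O)NC(=O)Nc4ccccn4)nn3)nc(Nc3cccc(Cl)c3)c2C#N)cc1`, 1130 nM
compound 2, `Cc1ccc(Nc2nc(SCc3cn(CC(=O)NC(=O)Nc4ccccn4)nn3)nc(-c3ccc(C(C)C)cc3)c2C#N)cc1`, 3060 nM
compound 3, `COc1cc(-c2nc(SCc3cn(CC(=O)NC(=O)Nc4ccccn4)nn3)nc(Nc3ccc(C)cc3)c2C#N)cc(OC)c1OC`, 32 nM

In a functional assay on B16-F10 cells (Mus musculus) for inhibition, read by MTT assay, with a stated time of 72 h (a higher number here means a weaker inhibitor, a lower number a stronger inhibitor), compound 3 stands lowest of the three numbers; compound 1 is the nearest to it and compound 2 the furthest, both well beyond the scatter. Compound 4, `COc1cc(-c2nc(SCc3cn(CC(=O)NC(=O)Nc4ccccn4)nn3)nc(Nc3cccc(Cl)c3)c2C#N)cc(OC)c1OC`, differs from compound 3 in one place: 3-chlorophenyl in place of 4-methylphenyl on a nitrogen on an aromatic ring.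

Among the measured compounds shown here, one measured step bears directly on this change. Between compound 1 and compound 2, where the core carries 4-isopropylphenyl, the same pair of anilino groups was exchanged in the opposite direction, and the result was a 2.7-fold higher number from compound 1 to compound 2 (0.43 log units; beyond the scatter). Reversing that exchange on the core of compound 3 would therefore be expected to lower the number by a similar modest amount. The step of a 96-fold lower number from compound 2 to compound 3 (1.98 log units; beyond the scatter) shows that the core change dominates the series, but says nothing about whether the anilino effect carries over unchanged.

On that basis compound 4 is expected to be a somewhat stronger inhibitor than compound 3, with the expected step being a 2.1-fold lower number from compound 3 to compound 4 (0.33 log units; beyond the scatter). The estimated value for compound 4 in this assay is 15 nM, with a plausible range from 5 nM to 50 nM.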

Compound 4, half-maximal inhibitory concentration: 1420 nM
Beside the measured number, compound 4's estimate is 95-fold (1.98 log units) below it; measured number above the stated range.
By their numbers in this assay, from the lowest: compound 3; then compounds 1 and 4 (each within the scatter of the next); then compound 2.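

The exchange of 4-methylphenyl for 3-chlorophenyl on this nitrogen has no fixed effect: in this assay, the core of compound 3 gives a 44-fold higher number from compound 3 to compound 4 (1.65 log units; beyond the scatter), a large change in the opposite direction to the modest one seen on the core of compound 1: the same change on two cores in this assay, a 2.7-fold higher number (0.43 log units; beyond the scatter) from compound 1 to compound 2 and a 44-fold lower number (1.65 log units; beyond the scatter) from compound 4 to compound 3, 120-fold (2.08 log units) apart, beyond the scatter of two such steps. The core change is just as dependent on its partner, for 3,4,5-trimethoxyphenyl in place of 4-isopropylphenyl brought the large gain only with 4-methylphenyl on the nitrogen, whereas with 3-chlorophenyl there it gives a 1.3-fold higher number from compound 1 to compound 4 (0.10 log units; within the scatter): the same change on two cores in this assay, a 96-fold lower number (1.98 log units; beyond the scatter) from compound 2 to compound 3 and a 1.3-fold higher number (0.10 log units; within the scatter) from compound 1 to compound 4, 120-fold (2.08 log units) apart, beyond the scatter of two such steps. The two places therefore do not act independently in these four compounds, and the low number of compound 3 belongs to the pairing of 3,4,5-trimethoxyphenyl with 4-methylphenyl rather than to either group alone.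

The compounds shown leave open whether that pairing depends on the methyl group itself, on the place of the substituent on the ring, or on the absence of chlorine. A 3-methylphenyl or a 4-chlorophenyl group on the same nitrogen of the core of compound 3 would separate these readings, and an unsubstituted phenyl would give both a common reference.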